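A few compounds are considered here, and "the series" means these few. Any claim that something is new, unique, unknown or untested is made for them only; others in the source may bear on it.

Measured so far:
compound 1, `O=C(COc1ccc2cc(/C=C3/SC(=O)NC3=O)ccc2c1)Nc1ccc(F)cc1F`: > 50000 nM
compound 2, `O=C(COc1ccc2cc(/C=C3/SC(=O)NC3=O)ccc2c1)Nc1ccc(F)cc1`: 6600 nM

In an assay on isolated protein for inhibition of histone deacetylase 8 (Homo sapiens), with a stated time of 1 h (a lower number here means a stronger inhibitor, a higher number a weaker inhibitor), compound 1 gives only a limit, not a number: the limit of > 50000 nM in this assay, at which 1 of the 2 values shown sits. Compound 2 gives 6600 nM in this assay; the change was hydrogen in place of fluoro on an aromatic carbon, and the number moved by an at least 7.5-fold lower number from compound 1 to compound 2 (0.87 log units; beyond the scatter). Compound 3, `Cc1ccc(NC(=O)COc2ccc3cc(/C=C4/SC(=O)NC4=O)ccc3c2)cc1Cl`, has not yet been measured in this assay. It differs from compound 1 by 3-chloro-4-methylphenyl in place of 2,4-difluorophenyl on an amide-type nitrogen. Among the compounds with values here, only one measured step bears on this, the one from the difluoro compound to the monofluoro compound, and it is a smaller change than the one to compound 3, where both fluoro leave and chloro plus methyl enter. A downward step of at least similar size is expected, an at least 6.2-fold lower number from compound 1 to compound 3 (0.79 log units; beyond the scatter), though it cannot be sized exactly from a limit. Compound 3 is therefore estimated at 8000 nM, with a range from 1500 nM to 50000 nM.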

Compound 3, half-maximal inhibitory concentration: > 50000 nM
Compound 3 was reported as a limit; the forecaster's own chance of this, stated with the estimate: 30%; middle value at least 6.2-fold (0.79 log units) from the limit.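

At this position on the amide-type nitrogen, in this assay, 3-chloro-4-methylphenyl in place of 4-fluorophenyl gives an at least 7.5-fold higher number from compound 2 to compound 3 (0.87 log units; beyond the scatter). The earlier pair showed a drop in strength only with a second fluoro on the ring, whereas compound 3 shows that a ring with no fluoro at all, carrying chloro and methyl instead, also falls out of the measurable range, so the low result of compound 1 is not unique to 2,4-difluorophenyl: the limit of > 50000 nM in this assay, at which 2 of the 3 values shown sit. The step between compound 1 and compound 3 cannot be read, as both values are limits.

Chloro and methyl enter together in compound 3, and which of them drives the drop stays open. Also open, from the compounds shown here alone, is how plain phenyl, 4-chlorophenyl, 4-methylphenyl or a phenyl ring carrying an amine would behave at this place.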